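The compounds below may be only part of what the source reports. "The series", "measured", "known", "first", "only" and "open" are said of these compounds alone.

Among the measured compounds shown here, in a functional assay for agonist activity at G protein-coupled receptor 88 (Homo sapiens), read by HTRF and cAMP accumulation (a higher number here means that more compound is needed for the effect, a lower number that less compound is needed), compound 2 `CC[C@H](C)[C@H](N)CN(C(=O)[C@@H]1C[C@H]1c1ccccc1)c1ccc(-c2ccc(C(F)(F)F)cc2)cc1` gives 340 nM, the highest of the two numbers known here. Compound 1 `CCc1ccc(-c2ccc(N(C[C@@H](N)[C@@H](C)CC)C(=O)[C@@H]3C[C@H]3c3ccccc3)cc2)cc1` gives 44 nM, and the change is a 7.7-fold higher number from compound 1 to compound 2 (0.89 log units; beyond the scatter). Compound 3 `CC[C@H](C)[C@H](N)CN(C(=O)[C@@H]1C[C@H]1c1ccccc1)c1ccc(-c2ccc(OC(C)C)cc2)cc1` differs from compound 2 by isopropoxy in place of trifluoromethyl on an aromatic carbon. For the measured compounds named here, no measured step involves isopropoxy itself; the single known step, between ethyl and trifluoromethyl at this same place, shows only that this part of the molecule can shift the number beyond the scatter. Compound 3 is therefore expected to move back toward compound 1, with a 3.1-fold lower number from compound 2 to compound 3 (0.49 log units; beyond the scatter). The estimate for compound 3 is 110 nM, with a range from 30 nM to 450 nM.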

Compound 3, half-maximal effective concentration: 72 nM
Beside the measured number, compound 3's estimate is 1.5-fold (0.18 log units) above it; measured number inside the range.
By their numbers in this assay, from the lowest: compounds 1 and 3 (each within the scatter of the next); then compound 2.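

Isopropoxy in place of trifluoromethyl gives a 4.7-fold lower number from compound 2 to compound 3 (0.67 log units; beyond the scatter) in this assay, so the higher number seen with trifluoromethyl does not extend to every group at this place. Isopropoxy in place of ethyl gives a 1.6-fold higher number from compound 1 to compound 3 (0.21 log units; within the scatter), so two different groups, one carrying an oxygen and one of carbon only, give numbers that cannot be told apart. Nothing available here explains these differences.

Still open, as far as these compounds go, is what an amine, a carboxylic acid or a longer chain such as butoxy would do at this place. Also open, from the compounds shown here alone, is whether the oxygen of isopropoxy matters, which a plain isopropyl group would test.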